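Trifluoromethoxy for Methoxycarbonyl: a Step Not Yet Measured

The source may hold more compounds than are shown below. What is called first, only, known or untested is meant among the compounds shown, and "the series" means these compounds.

Compound 1, `COC(=O)c1cccc(C(=O)N2CCC(N(C3CC3)S(=O)(=O)c3cccc(C(F)(F)F)c3)CC2)c1`, gives 380 nM in an assay on HEK293 cells for inhibition of Voltage-dependent N-type calcium channel subunit alpha-1B (Homo sapiens), read by FLIPR and calcium flux, in the presence of a further agent that is not named here; on this read-out lower numbers stand for stronger inhibition and higher numbers for weaker inhibition.
Compound 2, `CCCN(C1CCN(Cc2c(OC)cccc2OC)CC1)S(=O)(=O)c1cccc(C(F)(F)F)c1`, gives 120 nM in this assay.

Of the compounds shown here, two have been measured in this assay, and compound 1 stands at the higher of the two numbers. Its nearest neighbour, compound 2, sits at a lower number, and the gap between them is beyond the usual scatter. The two compounds differ in more than one place, so nothing can be drawn from that gap about any single change.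

Compound 3, `O=C(c1cccc(OC(F)(F)F)c1)N1CCC(N(C2CC2)S(=O)(=O)c2cccc(C(F)(F)F)c2)CC1`, differs from compound 1 in one place only: trifluoromethoxy in place of methoxycarbonyl on an aromatic carbon. Among the measured compounds shown here, no measured pair in this set isolates that change, so there is no step on which to rest a firm direction. The change keeps the ring and its other substituent unaltered, and an exchange of this kind is expected to move the number in this assay little, if at all, beyond the scatter, with perhaps a slight lean toward a lower number.

On that basis compound 3 is estimated at 250 nM in this assay, within a range of 80 nM to 800 nM. The expected step is a 1.5-fold lower number from compound 1 to compound 3 (0.18 log units; within the scatter).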

Compound 3, half-maximal inhibitory concentration: 370 nM
The estimate for compound 3 lay 1.5-fold (0.17 log units) below the measured number, within the range that was stated.
By their numbers in this assay, from the lowest: compound 2; then compounds 3 and 1 (each within the scatter of the next).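

In this assay, trifluoromethoxy in place of methoxycarbonyl on an aromatic carbon, meta to a large group, gives the set's only single-place step (a 1.0-fold lower number from compound 1 to compound 3 (0.01 log units; within the scatter)), so this change can now be read on its own. Going from 3-(methoxycarbonyl)phenyl to 3-(trifluoromethoxy)phenyl leaves compounds 1 and 3 indistinguishable on this read-out, even though only the first group holds a double bond outside the aromatic ring and only the second holds fluorine. Nothing in the data explains why these two groups read alike.

What the compounds shown leave open is whether this insensitivity extends beyond these two groups, since a single step cannot show how an amine, a carboxylic acid or a longer chain at the same place would read. It also remains open which of the several differences separating compound 2 from compounds 1 and 3 accounts for its lower number, as no single-place step connects compound 2 to either of them.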